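Replacing a nitrile-bearing ring with a dichlorophenyl on a sulfonyl

The compounds below may be only part of what the source reports. "The series", "measured", "known", "first", "only" and "open" are said of these compounds alone.

Measured so far:
compound 1 `CC1CCN(c2c(S(=O)(=O)c3ccc(C#N)cc3)cnc3cc(F)ccc23)CC1`, 83%
compound 2 `CC1CCN(c2c(S(=O)(=O)c3cc(F)cc(F)c3)cnc3c(F)cccc23)CC1`, 9%

Among the compounds with values here, in an assay on isolated protein for displacement of a labelled ligand from metabotropic glutamate receptor 5 (Homo sapiens), with a stated time of 60 min, tested at 1 uM (a lower number here means less inhibition, a higher number more inhibition at the concentration tested (going by the name of the read-out)), compound 1 gives 83%, the higher of the two numbers known here. Compound 2 gives 9% in this assay, a gap beyond the scatter, but compound 2 differs from compound 1 in more than one place, so the two values alone do not tell which change matters.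

Compound 3 `CC1CCN(c2c(S(=O)(=O)c3cc(Cl)cc(Cl)c3)cnc3cc(F)ccc23)CC1` is not yet measured. It keeps the core of compound 1 and changes only the ring on the sulfonyl sulfur: 3,5-dichlorophenyl in place of 4-cyanophenyl on a sulfonyl sulfur. The new ring carries two chlorines and no hydrogen-bond acceptor, where the old ring carried a nitrile.

Within the data shown here, with no measured step of this exact kind, the expectation leans on the low value of compound 2, whose ring on the sulfonyl also carries two halogens; a drop from compound 1 to compound 3 is therefore expected, of size a number 33 percentage points lower from compound 1 to compound 3 (beyond the scatter), though with wide uncertainty. Compound 3 is estimated at 50% in this assay, with a range from 15% to 85%.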

Compound 3, a percentage reported as inhibition, at one concentration (the size of the read-out at that concentration, not a potency): 87%
For compound 3 the middle estimate is 37 percentage points below the measured one; measured number outside the range, above it.
By their numbers in this assay, from the lowest: compound 2; then compounds 1 and 3 (each within the scatter of the next).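

In this assay, putting 3,5-dichlorophenyl in place of 4-cyanophenyl on a sulfonyl sulfur gives a number 4 percentage points higher from compound 1 to compound 3 (within the scatter), so the two rings cannot be told apart by this read-out. At this position, then, the nitrile and its hydrogen-bond acceptor are not required to keep the inhibition seen with compound 1, since the ring in compound 3 has no hydrogen-bond acceptor and carries two chlorines instead. Nothing available here explains why two such different rings give matching results.

As far as these compounds go, it remains open whether a phenyl ring bearing an amine or a carboxylic acid, or a plain phenyl ring with no substituent, would also hold up on the sulfonyl sulfur, and whether compound 1 and compound 3 would still match in a full potency measurement, since this read-out comes from a single concentration. Also unresolved is which of the several differences between compound 1 and compound 2 goes with the value of 9%, as compound 2 differs from compound 3 in more than one place as well.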